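The source may report more compounds than this note shows. Statements on the series, on what has been measured and on what is new or still open speak of the compounds shown alone.

Measured so far in an ADME assay on MDBK cells (Bos taurus) for cytotoxicity, read by MTT assay, with a stated time of 96 h; a higher number here means that more compound is tolerated, a lower number that less compound is tolerated:
compound 1, `COc1ccc(-c2nc3cc(C(C)=O)ccc3[nH]2)c(OC)c1OC`: > 100000 nM
compound 2, `COc1ccc(-c2nc3cc([N+](=O)[O-])ccc3[nH]2)c(OC)c1`: > 100000 nM
compound 3, `O=C(CN1CCCC1)Nc1ccc(-c2nc3ccccc3[nH]2)cc1`: 70000 nM.

Compound 1 reports a limit of the assay and not a number, > 100000 nM. For compound 2 the result is likewise only a limit, > 100000 nM. Compound 2 thus stands at the limit of > 100000 nM in this assay, at which 2 of the 3 values shown sit, and nothing finer than that is known of it. Within the data shown here, compound 3 is the one member of the set with a measured number, 70000 nM.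

Compound 4, `COc1ccc(-c2nc3cc(C(C)=O)ccc3[nH]2)c(OC)c1`, is still to be measured in this assay. It differs from compound 2 in one place: acetyl in place of nitro on an aromatic carbon. Compound 1 already carries the acetyl group on the same kind of position and also reports only a limit in this assay, so the acetyl-bearing core is not seen to be less tolerated than the nitro-bearing one.

Among the measured compounds shown here, no step between measured compounds is available to set the size of this change. The expectation is therefore that the step from compound 2 to compound 4 stays within the scatter, with no change in direction, and that compound 4 again reaches the limit. The estimate for compound 4 in this assay is 120000 nM, with a range from 50000 nM to 300000 nM, which is expected to mean a step that the limit leaves unreadable from compound 2 to compound 4.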

Compound 4, half-maximal cytotoxic concentration: > 100000 nM
Compound 4 ended at the assay's limit (the forecaster's own chance of this, stated with the estimate: 70%); the middle value is on the limit's open side.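

In this assay compound 4 gives > 100000 nM, a limit of the assay and not a number. Among these compounds, compound 1 and compound 2 also report only limits, so no step from either to compound 4 can be read. Compound 4 stands with them: the limit of > 100000 nM in this assay, at which 3 of the 4 values shown sit.

The compounds shown leave open whether acetyl in place of nitro, or hydrogen in place of methoxy, changes tolerance at all in this series.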